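Swapping the naphthyl sulfonyl arm for a dichlorophenyl one

A few compounds are considered here, and "the series" means these few. Any claim that something is new, unique, unknown or untested is made for them only; others in the source may bear on it.

Among the compounds with values here, compound 1 `CC(C)Cc1cc(CNS(=O)(=O)c2cccc3ccccc23)nn1-c1ccccc1` is the only member of this small set with a number: in a functional assay on HeLa cells for antagonist activity at 5-hydroxytryptamine receptor 6 (Homo sapiens), read by HTRF and cAMP accumulation, with stated times of 10 min and 30 min (on this read-out higher numbers stand for weaker inhibition and lower numbers for stronger inhibition), compound 1 gives 2430 nM. Its companion compound 2 `CC(C)Cc1cc(CNS(=O)(=O)Cc2cccc3ccccc23)nn1-c1ccccc1`, which carries a methylene between the sulfonyl and the naphthalene, has no number; for compound 2 the result in this assay is "not determined" (no result reported). Within the data shown here, no step between two measured compounds can therefore be read from the set. The unmeasured compound 3 `CC(C)Cc1cc(CNS(=O)(=O)c2c(Cl)cccc2Cl)nn1-c1ccccc1` differs from compound 1 in one place: 2,6-dichlorophenyl in place of naphthalen-1-yl on a sulfonyl sulfur. Among the measured compounds shown here, with no measured step to lean on, the expectation for compound 3 rests on compound 1 alone and its 2430 nM, and the step of a 1.2-fold higher number from compound 1 to compound 3 (0.09 log units; within the scatter) is expected to be small, within the usual scatter of this assay, in no clear direction. Compound 3 is thus estimated at 3000 nM in this assay, with a plausible range from 800 nM to 12000 nM.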

Compound 3, half-maximal inhibitory concentration: 5650 nM
Compound 3: the middle estimate sits 1.9-fold (0.27 log units) below what was measured; measured number inside the range.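

At this position on the sulfonyl sulfur, the aryl group does matter in this assay: 2,6-dichlorophenyl in place of naphthalen-1-yl gives a 2.3-fold higher number from compound 1 to compound 3 (0.37 log units; beyond the scatter), a modest step towards weaker inhibition. The position therefore tolerates the exchange of two aromatic rings for one chlorine-bearing ring at a modest cost, and compound 3 still gives a measurable result. Nothing available here explains this step.

From the compounds shown here alone, because the change removes the second ring and adds two chlorines at once, the shift cannot be assigned to either part, and whether a plain phenyl or a 2-chlorophenyl group on the sulfonyl sulfur would fall closer to compound 1 or compound 3 remains open. Steps involving compound 2 cannot be read, so the effect of its methylene also stays unknown.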